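Swapping difluorophenyl for trifluoromethylphenyl on the acyl urea

The compounds below may be only part of what the source reports. "The series", "measured", "known", "first", "only" and "open" are said of these compounds alone.

Among the compounds with values here, compound 2 `CN(C(=O)NC(=O)c1ccc(F)c(F)c1)c1nc(C(F)(F)F)c(C(=O)N/N=C/c2cccc(C(F)(F)F)c2)s1` stands as the lower of the two values measured so far in a functional assay on HeLa cells (Homo sapiens) for inhibition, read by MTT assay, with a stated time of 72 h; a higher number here means a weaker inhibitor, a lower number a stronger inhibitor: compound 2 gives 4.21 ug/mL, while compound 1 `CN(C(=O)NC(=O)c1c(F)cccc1F)c1nc(C(F)(F)F)c(C(=O)N/N=C/c2cccc(C(F)(F)F)c2)s1` gives 21.6 ug/mL. Within the data shown here, the only measured step, a 5.1-fold lower number from compound 1 to compound 2 (0.71 log units; beyond the scatter), concerns the same aryl group on the carbonyl carbon. Compound 3 `CN(C(=O)NC(=O)c1cccc(C(F)(F)F)c1)c1nc(C(F)(F)F)c(C(=O)N/N=C/c2cccc(C(F)(F)F)c2)s1` differs from compound 2 by 3-(trifluoromethyl)phenyl in place of 3,4-difluorophenyl on a carbonyl carbon. The measured step bears on this only loosely: it shows that altering this aryl group can shift the number by a modest amount, but nothing measured exchanges fluorine for trifluoromethyl, so no direction can be read from it. Compound 3 is therefore expected to show a step of a 1.4-fold higher number from compound 2 to compound 3 (0.15 log units; within the scatter), not beyond the scatter. Compound 3 is estimated to give 6 ug/mL in this assay, within a range from 2 ug/mL to 18 ug/mL.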

Compound 3, half-maximal inhibitory concentration: 4.81 ug/mL
The estimate for compound 3 lay 1.2-fold (0.10 log units) above the measured number, and the stated range covers the measured number.
By their numbers in this assay, from the lowest: compounds 2 and 3 (each within the scatter of the next); then compound 1.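

In this assay, replacing 3,4-difluorophenyl with 3-(trifluoromethyl)phenyl on the carbonyl carbon gives a 1.1-fold higher number from compound 2 to compound 3 (0.06 log units; within the scatter), so the larger group, with 10 heavy atoms in place of 8, leaves the number within the scatter. Set against 2,6-difluorophenyl, the same group gives a 4.5-fold lower number from compound 1 to compound 3 (0.65 log units; beyond the scatter), which places compound 2 and compound 3 together and leaves compound 1, with its 2,6-difluorophenyl group, apart from both. Nothing measured here offers a reason for either step.

The compounds shown leave open whether an unsubstituted phenyl, or a phenyl carrying a chlorine or a methoxy group, would stay with compound 2 and compound 3 or move toward compound 1. They also leave open whether a 2-fluorophenyl group, with a single fluorine, would give a number like that of compound 1.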